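The source may report more compounds than this note shows. Statements on the series, on what has been measured and on what is new or still open speak of the compounds shown alone.

Compound 1 `O=C1COc2ccccc2N1CCCn1cc(-c2ccccn2)nn1`: 5800 nM
Compound 2 `O=C1COc2ccccc2N1CCCn1cc(-c2cccnc2)nn1`: 8200 nM
Compound 3 `O=C1COc2ccccc2N1CCCn1cc(CO)nn1`: 1010 nM

In a functional assay on MiaPaCa cells (Homo sapiens) for antiproliferative activity, read by sulforhodamine B assay, with a stated time of 48 h (a lower number here means a stronger inhibitor of growth, a higher number a weaker inhibitor of growth), compound 3 stands lowest of the three, at 1010 nM. Compound 4 `CCCc1cn(CCCN2C(=O)COc3ccccc32)nn1`, not yet measured, carries ethyl in place of hydroxy on a saturated chain carbon bound to an aromatic carbon. Going by the values given here, no measured step makes this exact change. The closest ones replace a pyridinyl group with hydroxymethyl: a 5.7-fold lower number from compound 1 to compound 3 (0.76 log units; beyond the scatter) and an 8.1-fold lower number from compound 2 to compound 3 (0.91 log units; beyond the scatter). The swap between pyridinyl groups, a 1.4-fold higher number from compound 1 to compound 2 (0.15 log units; within the scatter), says little here. Losing the hydroxymethyl group is therefore expected to raise the number in this assay modestly, with an estimated 3.0-fold higher number from compound 3 to compound 4 (0.47 log units; beyond the scatter). For compound 4 the estimate is 3000 nM, with an expected range of 900 nM to 10000 nM.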

Compound 4, concentration for 50% growth inhibition: 2600 nM
Compound 4: middle estimate off by 1.2-fold (0.06 log units), on the high side; low and high end bracket the measured number.
By their numbers in this assay, from the lowest: compound 3; then compound 4; then compounds 1 and 2 (each within the scatter of the next).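

In this assay, swapping the hydroxy end of the side chain for ethyl costs only a modest amount, a 2.6-fold higher number from compound 3 to compound 4 (0.41 log units; beyond the scatter), so the hydroxy group is not essential for growth inhibition at this place. The plain propyl chain also outperforms both pyridinyl groups, a 3.2-fold lower number from compound 2 to compound 4 (0.50 log units; beyond the scatter) and a 2.2-fold lower number from compound 1 to compound 4 (0.35 log units; beyond the scatter), which shows that the pyridinyl compounds' weaker numbers are not made up for by the aromatic ring they carry. Nothing available accounts for these differences.

As far as these compounds go, it remains open whether an amine, a carboxylic acid or a longer chain on this carbon would match compound 3. A methyl ether would test whether the free hydroxy itself matters.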